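Chloro for Methoxy on the Thiourea Aryl Ring

A few compounds are considered here, and "the series" means these few. Any claim that something is new, unique, unknown or untested is made for them only; others in the source may bear on it.

Measured compounds:
compound 1, `COc1cccc(NC(=S)NCCNS(=O)(=O)c2ccc(-c3ccccc3Oc3ccc([N+](=O)[O-])cc3)s2)c1` — > 20000 nM
compound 2, `COc1ccc(Oc2ccc([N+](=O)[O-])cc2-c2ccsc2S(=O)(=O)N2CCN(C(=O)Nc3ccc([N+](=O)[O-])cc3)CC2)cc1OC` — > 20000 nM
compound 3, `O=C(NCCNS(=O)(=O)c1ccc(-c2ccccc2Oc2ccc([N+](=O)[O-])c([N+](=O)[O-])c2)s1)Nc1cc(Cl)cc(Cl)c1` — > 20000 nM

In an ADME assay on HEK-293T cells (Homo sapiens) for cytotoxicity, read by CCK-8 assay, with a stated time of 48 h (on this read-out lower numbers stand for stronger inhibition and higher numbers for weaker inhibition), compound 1 gives > 20000 nM, which is a limit of the assay and not a number. Compound 2 likewise gives > 20000 nM, again a limit. Compound 3 gives > 20000 nM, a limit as well. Compound 1 therefore stands where every shown value stands: the limit of > 20000 nM in this assay, at which 3 of the 3 values shown sit. Among the compounds with values here, no step between two measured compounds that differ in a single place has been recorded in this set, so the three values say only that none of the compounds reached a measurable cytotoxicity.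

Compound 4, `O=[N+]([O-])c1ccc(Oc2ccccc2-c2ccc(S(=O)(=O)NCCNC(=S)Nc3cccc(Cl)c3)s2)cc1`, is to be measured in this assay. It differs from compound 1 by chloro in place of methoxy on an aromatic carbon. Within the data shown here, with compound 1 at the limit and nothing among the measured compounds pointing in either direction, the step expected from compound 1 to compound 4 is a step that the limit leaves unreadable from compound 1 to compound 4, that is, none beyond the scatter. Compound 4 is thus expected to give about 25000 nM in this assay, within a range of 10000 nM to 60000 nM, and most likely the assay will again report only a limit rather than a number.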

Compound 4, half-maximal inhibitory concentration: 4990 nM
For compound 4 the middle estimate is 5.0-fold (0.70 log units) above the measured one; the whole stated range lies above it.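

In this assay, putting chloro in place of methoxy on the aromatic carbon, the change from 3-methoxyphenyl to 3-chlorophenyl, gives an at least 4.0-fold lower number from compound 1 to compound 4 (0.60 log units; beyond the scatter). Within the data shown here, this shows that a single substituent at this position of the shared core can move the read-out beyond the scatter, something that the earlier compounds, all held at a limit, could not show. Among these compounds, with compound 4 at 4990 nM, the set gains its only number, and the step is a minimum whose true size may be larger, as compound 4 stands alone among the values shown: the limit of > 20000 nM in this assay, at which 3 of the 4 values shown sit.

The compounds shown leave open whether this result belongs to chloro in particular or would also appear with fluoro, bromo, trifluoromethyl, an amine or a carboxylic acid at the same position. They also leave open whether chloro would give the same step on a different aromatic carbon of this ring, or with a urea in place of the thiourea, and nothing shown says why the number drops.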